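This account rests on a few compounds, and the source may have more. Where it says the series, first, only, none or still open, it means among the compounds named here.

Working notes on the series. Compound 1 `O=C(O)Cc1sc(C(c2ccc(F)cc2)c2ccc(F)cc2)nc1-c1ccc(Cl)cc1` gives 80% in an in vitro functional assay on HEK285-7 cells for antagonist activity at prostaglandin D2 receptor 2 (Homo sapiens), read by BRET and beta-arrestin recruitment (on this read-out higher numbers stand for larger maximal responses and lower numbers for smaller maximal responses), and stands level with compound 3 `O=C(O)Cc1sc(C(c2ccccc2)c2ccc(F)cc2)nc1-c1ccc(Cl)cc1`, which gives 80%; together they are the highest of the three numbers, and compound 2 `O=C(O)Cc1sc(C2COc3ccccc3O2)nc1-c1ccc(Cl)cc1`, at 50%, sits a long way under them. Within the data shown here, the only single-place step measured is no change at the digits printed from compound 1 to compound 3 (within the scatter), hydrogen in place of fluoro on an aromatic carbon of the diaryl group, which did nothing beyond the scatter.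

Compound 4 `O=C(O)Cc1sc(C(c2ccc(F)cc2)c2ccc(F)cc2)nc1-c1ccnc(F)c1` differs from compound 1 by 2-fluoropyridin-4-yl in place of 4-chlorophenyl on an aromatic carbon. Among the measured compounds shown here, no measured step touches the group on the five-membered aromatic ring with 1 nitrogen and 1 sulfur, so the step from compound 1 to compound 3 bears on the present change only loosely: it shows that a change on one aromatic ring left the largest response unchanged, but it is not the same place. The gap between compound 1 and compound 2 concerns yet another part of the molecule. The expected step is therefore small, with no direction and wide uncertainty, a number 8 percentage points lower from compound 1 to compound 4 (within the scatter). For compound 4 the estimate is 72%, expected to fall between 50% and 90%.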

Compound 4, largest response reached (reported as efficacy), in percent of the reference or control that the assay uses: 80%
Beside the measured number, compound 4's estimate is 8 percentage points below it; the range from low to high includes it.
By their numbers in this assay, from the lowest: compound 2; then compounds 1, 3 and 4 (each within the scatter of the next).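

In this assay, among these compounds, the only step read at this position gives no change at the digits printed from compound 1 to compound 4 (within the scatter) with 2-fluoropyridin-4-yl in place of 4-chlorophenyl on the aromatic carbon next to the ring nitrogen. The largest response therefore holds across a change from a six-membered aromatic ring of carbon only, with 0 hydrogen-bond acceptors, to a six-membered aromatic ring with 1 hetero atom and 1 hydrogen-bond acceptor. No supporting data on hand bear on this result.

A single replacement at this position leaves open whether an aliphatic group such as cyclopropyl, or a ring carrying an amine or a carboxylic acid, would also hold the largest response. Also open, on these data alone, is whether 2-fluoropyridin-4-yl would hold it alongside the large group of compound 2.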